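The source may hold more compounds than are shown below. What is called first, only, known or untested is meant among the compounds shown, and "the series" means these compounds.

Measured so far:
compound 1, `Nc1nc(Cl)c(-c2nc3ccccc3s2)c(N[C@@H]2C[C@H](CO)[C@@H](O)[C@H]2O)n1`, 14000 nM
compound 2, `CCOC(=O)NCCNc1nc(C)c(-c2nc3ccccc3s2)c(N[C@@H]2C[C@H](CO)[C@@H](O)[C@H]2O)n1`, 12000 nM

Both numbers come from an ADME assay on cells (Homo sapiens) for cytotoxicity, read by polymerase chain reaction, with a stated time of 3 days; on this read-out lower numbers stand for higher toxicity in this test and higher numbers for lower toxicity in this test. Compound 2 gives 12000 nM and compound 1 gives 14000 nM; the two lie within the scatter of each other, so no difference between them can be read. Compound 3, `Cc1nc(NCc2ccncc2)nc(N[C@@H]2C[C@H](CO)[C@@H](O)[C@H]2O)c1-c1nc2ccccc2s1`, has not been measured in this assay. Its change from compound 2 is pyridin-4-yl in place of ((ethoxycarbonyl)amino)methyl on a saturated chain carbon bound to a nitrogen on an aromatic ring. Among the compounds with values here, no measured pair shows this change, so nothing beyond the two numbers at hand supports an expectation. The step of no change at the digits printed from compound 2 to compound 3 (within the scatter) is expected to lie within the scatter, in no clear direction. The estimate for compound 3 in this assay is 12000 nM, range 5000 nM to 30000 nM.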

Compound 3, half-maximal cytotoxic concentration: 7000 nM
Compound 3: the middle estimate sits 1.7-fold (0.23 log units) above what was measured; the range from low to high includes it.
By their numbers in this assay, from the lowest: compounds 3, 2 and 1 (each within the scatter of the next).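

In this assay, pyridin-4-yl in place of ((ethoxycarbonyl)amino)methyl on a saturated chain carbon bound to a nitrogen on an aromatic ring gives a 1.7-fold lower number from compound 2 to compound 3 (0.23 log units; within the scatter). At this position, then, a six-membered aromatic ring and an open chain carrying a carbonyl give no readable difference on this read-out. No measurement at hand bears on the reason for this result.

Going by these compounds, whether an amine, a carboxylic acid or a longer chain at this place would give a step beyond the scatter remains open. So does the outcome with phenyl in place of pyridin-4-yl.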